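Series notes: pyrimidine ether ureas, compound 3 to compound 4

The compounds below may be only part of what the source reports. "The series", "measured", "known", "first", "only" and "open" are said of these compounds alone.

The shared core carries a urea linked through an ether to a six-membered aromatic ring with two nitrogens, and the substituent on that ring is varied. Compound 1 `C=CC(=O)Nc1cc(Oc2ccc(NC(=O)Nc3ccc(C)c(C(F)(F)F)c3)cc2)ncn1` gives 1940 nM in a functional assay on BaF3 cells (Mus musculus) for inhibition, read by CCK-8 assay, with a stated time of 72 h; a higher number here means a weaker inhibitor of growth, a lower number a stronger inhibitor of growth. Compound 2 `CC(=O)Nc1cc(Oc2ccc(NC(=O)Nc3ccc(C)c(C(F)(F)F)c3)cc2)ncn1` gives 3230 nM, and the step of a 1.7-fold higher number from compound 1 to compound 2 (0.22 log units; within the scatter) lies within the scatter. Compound 3 `Cc1ccc(NC(=O)Nc2ccc(Oc3cc(N4CCNC[C@@H]4C)ncn3)cc2)cc1C(F)(F)F` gives 8120 nM, the highest of the three numbers; the nearest is compound 2 and the furthest compound 1, both steps beyond the scatter.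

Compound 4 `Cc1ccc(NC(=O)Nc2ccc(Oc3cc(NCCO)ncn3)cc2)cc1C(F)(F)F` differs from compound 3 in one place: (2-hydroxyethyl)amino in place of 2-methylpiperazin-1-yl on an aromatic carbon. Among the compounds with values here, the steps that bear on this are a 4.2-fold higher number from compound 1 to compound 3 (0.62 log units; beyond the scatter) and a 2.5-fold higher number from compound 2 to compound 3 (0.40 log units; beyond the scatter), both modest and both pointing to a higher number when the 2-methylpiperazin-1-yl group replaces an acylamino group on that aromatic carbon. Compound 4 carries an amino group there again, though not an acylamino one, so a partial move back toward the numbers of compound 1 and compound 2 is the expectation, rather than a full return. The estimated step is a 1.8-fold lower number from compound 3 to compound 4 (0.26 log units; within the scatter). For compound 4 the expected value in this assay is 4500 nM, with a range from 1800 nM to 12000 nM.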

Compound 4, concentration for 50% growth inhibition: > 10000 nM
Compound 4 was reported as a limit; the forecaster's own chance of this, stated with the estimate: 5%; at least 2.2-fold (0.34 log units) between middle value and limit.
By their numbers in this assay, from the lowest: compounds 1 and 2 (each within the scatter of the next); then compound 3. At a limit, above all of these: compound 4.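

The reading for compound 4 in this assay is a limit and not a number: the limit of > 10000 nM in this assay, at which 1 of the 4 values shown sits. Read as a floor, an at least 1.2-fold higher number from compound 3 to compound 4 (0.09 log units; that floor lies within the scatter), so these two compounds cannot be firmly ordered, but replacing 2-methylpiperazin-1-yl with (2-hydroxyethyl)amino, which removes the ring and the defined stereocentre, gives no lower number at this position. The floors of an at least 3.0-fold higher number from compound 2 to compound 4 (0.49 log units; beyond the scatter) and an at least 5.1-fold higher number from compound 1 to compound 4 (0.71 log units; beyond the scatter) extend what compound 3 showed: on this aromatic carbon, both the cyclic 2-methylpiperazin-1-yl group and the acyclic (2-hydroxyethyl)amino group, neither with a carbonyl on the attached nitrogen, give higher numbers than the two acylamino groups.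

Going by these compounds, how far compound 4 lies beyond its limit remains open, and with it the true size of all three steps. Also open, on these data alone, is which feature of the acylamino groups goes with the lower numbers, a question that a methylamino group, a longer chain such as 3-hydroxypropylamino, or a piperazine lacking the methyl group could help to separate from the effect of the carbonyl.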